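A few compounds are considered here, and "the series" means these few. Any claim that something is new, unique, unknown or untested is made for them only; others in the source may bear on it.

Three acids of the same type have been run in a functional assay on K562 cells (Homo sapiens) for inhibition, read by MTT assay, with a stated time of 72 h; a lower number here means a stronger inhibitor, a higher number a weaker inhibitor. Compound 1 `CC(C)c1ccc(C(=O)/C=C/C(=O)O)c(C(C)C)c1` gives 4680 nM, and compound 2 `CC(C)c1ccc(C(C)C)c(C(=O)/C=C/C(=O)O)c1` gives 3280 nM. Compound 3 `CC(C)(C)c1ccc(C(=O)/C=C/C(=O)O)cc1` gives 4330 nM in this assay, a number that lies between those of compound 1 and compound 2, with both gaps within the usual scatter, so the three stand level on what is known.

Compound 4 `CCc1ccc(C(=O)/C=C/C(=O)O)cc1` differs from compound 3 in one place: ethyl in place of tert-butyl on an aromatic carbon. Going by the values given here, no pair of measured compounds shows this change, and the three numbers in hand give no pull in either direction, so the step from compound 3 to compound 4 is expected to stay within the scatter, at a 1.0-fold higher number from compound 3 to compound 4 (0.02 log units; within the scatter).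

Compound 4 is accordingly estimated at 4500 nM in this assay, within a range of 2000 nM to 10000 nM.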

Compound 4, half-maximal inhibitory concentration: 5530 nM
The estimate for compound 4 lay 1.2-fold (0.09 log units) below the measured number, within the range that was stated.
By their numbers in this assay, from the lowest: compounds 2, 3, 1 and 4 (each within the scatter of the next).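

In this assay, ethyl in place of tert-butyl on this aromatic carbon gives a 1.3-fold higher number from compound 3 to compound 4 (0.11 log units; within the scatter). Going by these compounds alone, this is the first single-place step, and it shows that at this position the number does not respond measurably to the exchange of these two alkyl groups. Nothing at hand speaks to why the two groups stand level.

Going by these compounds, whether an amine or a methoxy group at this aromatic carbon would move the number beyond the scatter remains open. So does the effect of an amide in place of the carboxylic acid of the shared core.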